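Compound 4: methoxy replaces the amino side chain

The source may hold more compounds than are shown below. What is called first, only, known or untested is meant among the compounds shown, and "the series" means these compounds.

Measured in an ADME assay on microsomes from liver (Homo sapiens) for metabolic stability, read by LC-MS, with a stated time of 40 min, tested at 0.5 uM; on this read-out lower numbers stand for slow clearance and higher numbers for fast clearance:
- Compound 1 `CC(C)S(=O)(=O)c1cccc(NC(=O)c2cccnc2N2CCC3(CC2)CC3)c1`: 375 mL.min-1.g-1
- Compound 2 `CC(C)(C)NS(=O)(=O)c1cccc(NC(=O)c2ccc(NS(C)(=O)=O)cc2N2CCC3(CC2)CC3)c1`: 79 mL.min-1.g-1
- Compound 3 `CC(C)(O)CNc1ccc(C(=O)Nc2cccc(S(=O)(=O)C3CCCC3)n2)c(N2CCC3(CC2)CC3)c1`: > 399 mL.min-1.g-1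

Compound 3 stands at the limit of > 399 mL.min-1.g-1 in this assay, at which 1 of the 3 values shown sits. Its reading is a limit of the assay, not a number.

Compound 4 `COc1ccc(C(=O)Nc2cccc(S(=O)(=O)C3CCCC3)n2)c(N2CCC3(CC2)CC3)c1` carries methoxy in place of (2-hydroxy-2-methylpropyl)amino on an aromatic carbon. Among the measured compounds shown here, no measured pair differs in one place, so the expectation in this assay rests on little. Clearance is expected to stay fast, as compound 1, which carries neither group, gives 375 mL.min-1.g-1. Against this, compound 2 gives 79 mL.min-1.g-1. The expected change is a small fall, an at least 1.4-fold lower number from compound 3 to compound 4 (0.15 log units; that floor lies within the scatter). Compound 4 is estimated at 280 mL.min-1.g-1, in a range of 120 mL.min-1.g-1 to 399 mL.min-1.g-1.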

Compound 4, intrinsic clearance in microsomes: > 399 mL.min-1.g-1
Compound 4 gave a limit, no number (the forecaster's own chance of this, stated with the estimate: 30%); at least 1.4-fold (0.15 log units) between middle value and limit.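

In this assay compound 3 and compound 4 both give limits, not numbers, so no step can be read between them: the limit of > 399 mL.min-1.g-1 in this assay, at which 2 of the 4 values shown sit.

The compounds shown leave open how far methoxy in place of (2-hydroxy-2-methylpropyl)amino changes clearance.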